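From a Phenoxy Side Chain to a Phenethyl One

The source may report more compounds than this note shows. Statements on the series, on what has been measured and on what is new or still open speak of the compounds shown alone.

compound 1, `CC1=C(N2CC2)C(=O)C(COc2ccccc2)=C(N2CC2)C1=O`: 4.71
compound 2, `CC(C)C1=C(N2CC2)C(=O)C=C(N2CC2)C1=O`: 5.37
compound 3, `CC1=C(N2CC2)C(=O)C(C(C)C)=C(N2CC2)C1=O`: 5.21

Of the compounds shown here, three sharing one core have been tested in a functional assay on L1210 cells (Mus musculus), with a stated time of 12 days; a higher number here means a more potent compound, by a factor of ten per unit of this negative logarithm, a lower number a less potent compound. Compound 1 stands lowest of the three; compound 3 comes nearest to it and compound 2 lies furthest, and both gaps are beyond the scatter.

Compound 4 `CC1=C(N2CC2)C(=O)C(CCCc2ccccc2)=C(N2CC2)C1=O` differs from compound 1 in one place: phenethyl in place of phenoxy on a saturated chain carbon bound to a double-bonded ring carbon. For the measured compounds named here, the only measured single-place step is a number 0.16 log units lower from compound 2 to compound 3 (within the scatter), which concerns a methyl on the core rather than the side chain, so it does not bear on the change here. Going by the values given here, no measured step exchanges one side-chain group for another. What the values do show is that compound 1 gives 4.71, whereas compound 3, which carries an all-carbon isopropyl group instead, gives 5.21. That is a thin basis, but it points the same way as the change to an all-carbon phenethyl group.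

A modest rise is therefore expected, a number 0.29 log units higher from compound 1 to compound 4 (within the scatter), with wide uncertainty. Compound 4 is estimated at 5, with a range from 4.5 to 5.5.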

Compound 4, logarithm of the reciprocal of the active concentration, log(1/C): 4.21
Compound 4: the middle estimate sits 0.79 log units above what was measured, and the stated range ends above it.
By their numbers in this assay, from the lowest: compound 4; then compound 1; then compounds 3 and 2 (each within the scatter of the next).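

In this assay, this side-chain place proves sensitive to an exchange between two groups that each hold one six-membered aromatic ring of carbon only: phenethyl in place of phenoxy on a saturated chain carbon bound to a double-bonded ring carbon gives a number 0.50 log units lower from compound 1 to compound 4 (beyond the scatter) and so a step beyond the scatter. For the compounds shown here, the earlier compounds offered no measured step at this place, so this is the first direct sign that the side chain itself can shift the number while the rest of the shared core stays fixed. The exchange removes the oxygen and its hydrogen-bond acceptor and changes the group from 7 heavy atoms to 8, but these differences arrive together, and nothing available explains the lower number.

Whether the oxygen, the size of the group or something else accounts for the step remains open, and a single pair cannot settle it. An amine or a carboxylic acid on the phenyl ring, or a longer chain leading to that ring, would show how far this trend extends at the same place.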